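The source may hold more compounds than are shown below. What is called first, only, known or untested is meant among the compounds shown, and "the series" means these compounds.

Among the measured compounds shown here, in an ADME assay on MRC5 cells (Homo sapiens), read by MTT assay, with a stated time of 3 days (a higher number here means a weaker inhibitor, a lower number a stronger inhibitor), compound 1 `CNc1ncnc2[nH]cc(Sc3cccs3)c12` gives 148000 nM and compound 2 `Nc1ncnc2[nH]cc(Sc3cccs3)c12` gives 136000 nM, so compound 2 stands level with the only other measured compound. Compound 3 `c1csc(Sc2c[nH]c3ncnc(-c4cccs4)c23)c1` differs from compound 2 in one place: thiophen-2-yl in place of amino on an aromatic carbon. In words, thiophen-2-yl stands in place of amino on an aromatic carbon. For the measured compounds named here, only one measured step is available, a 1.1-fold lower number from compound 1 to compound 2 (0.04 log units; within the scatter), and it is small. That step exchanges only hydrogen for methyl on the nitrogen, while compound 3 loses the amino group altogether, so it offers no measure for this larger change. A moderate move toward a lower number in this assay is nevertheless expected, with wide uncertainty. The expected step is a 1.9-fold lower number from compound 2 to compound 3 (0.29 log units; within the scatter). The estimated value for compound 3 is 70000 nM, within an expected range from 20000 nM to 200000 nM.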

Compound 3, half-maximal inhibitory concentration: 54500 nM
Compound 3: middle estimate off by 1.3-fold (0.11 log units), on the high side; measured number inside the range.
By their numbers in this assay, from the lowest: compound 3; then compounds 2 and 1 (each within the scatter of the next).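

Among the compounds shown here, on the aromatic carbon next to the ring nitrogen, in this assay, thiophen-2-yl in place of amino gives a 2.5-fold lower number from compound 2 to compound 3 (0.40 log units; beyond the scatter), the first step here beyond the scatter, whereas hydrogen in place of methyl on the nitrogen gave only a 1.1-fold lower number from compound 1 to compound 2 (0.04 log units; within the scatter), which lies within it. Thiophen-2-yl in place of methylamino gives a 2.7-fold lower number from compound 1 to compound 3 (0.43 log units; beyond the scatter), also beyond the scatter, so replacing either nitrogen group at this place with the ring lowers the number modestly. No measurement at hand gives a reason for these steps.

The compounds shown leave open whether an aromatic ring is needed at this place, or whether a phenyl ring, a morpholine or a longer alkyl chain would lower the number as well. They also leave open whether the sulfur of the thiophen-2-yl matters, which a furan-2-yl group at the same carbon would address.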